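The source may report more compounds than this note shows. Statements on the series, on what has been measured and on what is new or still open speak of the compounds shown alone.

Measured so far:
compound 1 `Cc1ccc(SCc2ccc(/C=C/C(=O)Nc3ccccc3N)cc2)cc1`: 25.5%
compound 2 `Nc1ccccc1NC(=O)c1ccc(CSc2nccc(C(F)(F)F)n2)cc1`: 68.3%

In a functional assay on HeLa cells (Homo sapiens) for inhibition, read by CCK-8 assay, with a stated time of 72 h, tested at 2 uM (on this read-out higher numbers stand for more inhibition of growth at the one concentration tested and lower numbers for less inhibition of growth), compound 1 gives 25.5%, the lower of the two numbers. Compound 2 gives 68.3%, a gap beyond the scatter. Compound 3 `Nc1ccccc1NC(=O)/C=C/c1ccc(CSc2cccc3ccccc23)cc1` is not yet measured; it differs from compound 1 by naphthalen-1-yl in place of 4-methylphenyl on a sulfur. Among the compounds with values here, no measured pair shows this change, so there is no step to lean on. The step of a number 9.5 percentage points higher from compound 1 to compound 3 (within the scatter) is expected to be small, at most a modest rise near the edge of the scatter. Compound 3 is estimated at 35%, with a range from 15% to 60%.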

Compound 3, percent growth inhibition at one concentration: 20.6%
Estimate against measurement, compound 3: 14.4 percentage points above; the range from low to high includes it.
By their numbers in this assay, from the lowest: compounds 3 and 1 (each within the scatter of the next); then compound 2.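

In this assay, naphthalen-1-yl in place of 4-methylphenyl on a sulfur gives a number 4.9 percentage points lower from compound 1 to compound 3 (within the scatter), so the two compounds cannot be told apart on this read-out. At this position, then, a second six-membered aromatic ring of carbon only is tolerated without a step beyond the scatter. Nothing on hand explains this result.

Still open, on these data alone, is whether a group of another kind on the sulfur, such as an amine, a carboxylic acid or a longer alkyl chain, would separate from compound 1. Compound 2 differs from compound 1 and compound 3 in more than one place, so what sets its value apart remains unassigned.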